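A single stereocentre change from compound 1

The source may report more compounds than this note shows. Statements on the series, on what has been measured and on what is new or still open speak of the compounds shown alone.

Values in a functional assay on MCF7 cells (Homo sapiens) for cytotoxicity, read by CCK-8 assay, with a stated time of 14 h (on this read-out higher numbers stand for weaker inhibition and lower numbers for stronger inhibition), so far:
- compound 1 `CC(=O)OC[C@H]1O[C@@H](S[C@H]2CC(=O)[C@@H]3OC[C@H]2O3)[C@H](OC(C)=O)[C@@H](OC(C)=O)[C@@H]1OC(C)=O` gives 47100 nM here
- compound 2 `O=C1C[C@H](S[C@@H]2O[C@H](CO)[C@@H](O)[C@H](O)[C@H]2O)[C@H]2CO[C@@H]1O2` gives 366000 nM here
- compound 3 `O=C(O)c1ccccc1S[C@H]1CC(=O)[C@@H]2OC[C@H]1O2` gives 218000 nM here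

Compound 1 holds the lowest number of the three, and the numbers of compound 3 and compound 2 both lie higher, beyond the scatter. Compound 4 `CC(=O)OC[C@H]1O[C@@H](S[C@H]2CC(=O)[C@@H]3OC[C@H]2O3)[C@H](OC(C)=O)[C@@H](OC(C)=O)[C@H]1OC(C)=O` relates to compound 1 by the two compounds have the same atoms and bonds and differ only in configuration as drawn: 1 of 8 stereo elements differ; a stereocentre at a saturated ring carbon is drawn R in compound 1 and S in compound 4, with a stereocentre at a saturated ring carbon drawn R in compound 1 and S in compound 4. Within the data shown here, no measured pair shows a change of this kind, so the expectation in this assay is weakly founded: no step beyond the scatter, in either direction. The estimated 1.2-fold higher number from compound 1 to compound 4 (0.07 log units; within the scatter) is accordingly small. For compound 4 the expected value is 55000 nM, within an estimated range of 24000 nM to 125000 nM overall.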

Compound 4, half-maximal inhibitory concentration in the MCF7 assay: 344000 nM
The estimate for compound 4 lay 6.3-fold (0.80 log units) below the measured number; measured number outside the range, above it.
By their numbers in the MCF7 assay, from the lowest: compound 1; then compounds 3, 4 and 2 (each within the scatter of the next).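

Configuration at this saturated ring carbon matters in the MCF7 assay: compound 1 gives 47100 nM and compound 4 gives 344000 nM, and the change from R to S gives a 7.3-fold higher number from compound 1 to compound 4 (0.86 log units; beyond the scatter), the first step in the series confined to one place. In a physicochemical assay for lipophilicity (on this read-out higher numbers stand for higher lipophilicity and lower numbers for lower lipophilicity), compound 1 gives -1.13 and compound 4 gives -1.13, and the same change gives no change at the digits printed from compound 1 to compound 4 (within the scatter), so the partition coefficient does not separate the pair. The higher number for compound 4 can be assigned to this stereocentre alone because nothing else separates the two: the fact that compounds 1 and 4 differ only in the configuration as drawn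

Open, on these data alone, is whether the other stereocentres carry similar weight. Also open, as far as these compounds go, is whether R remains favoured when an amine or a longer acyl chain replaces the acetate groups.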